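From Compound 3 to Compound 4 at the Carbonyl Carbon

A few compounds are considered here, and "the series" means these few. Any claim that something is new, unique, unknown or untested is made for them only; others in the source may bear on it.

Of the compounds shown here, three sharing one core have been tested in a functional assay on isolated protein for inhibition of Glucose-dependent insulinotropic receptor (Homo sapiens), read by HTRF and cAMP accumulation; a lower number here means that less compound is needed, a higher number that more compound is needed for the effect. Compound 1 `Cc1nc(S(C)(=O)=O)ccc1Oc1ncnc(OC2CCN(C(=O)OC(C)(C)CF)CC2)c1F` gives 19.9 nM, compound 2 `Cc1nc(S(C)(=O)=O)ccc1Oc1ncnc(OC2CCN(C(=O)O[C@H](C)CF)CC2)c1F` gives 196 nM, and compound 3 `Cc1nc(S(C)(=O)=O)ccc1Oc1ncnc(OC2CCN(C(=O)OC3(C(F)(F)F)CCC3)CC2)c1F` gives 14.3 nM. Compound 3 holds the lowest of the three numbers, with compound 1 nearest to it, the gap being a 1.4-fold lower number from compound 1 to compound 3 (0.14 log units; within the scatter), and compound 2 furthest away, as shown by a 14-fold lower number from compound 2 to compound 3 (1.14 log units; beyond the scatter). For the measured compounds named here, the only other step, a 9.8-fold higher number from compound 1 to compound 2 (0.99 log units; beyond the scatter), again points to the group on the oxygen next to the carbonyl as a place where the number moves.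

Compound 4 `Cc1nc(S(C)(=O)=O)ccc1Oc1ncnc(OC2CCN(C(=O)c3noc(C(C)C)n3)CC2)c1F` departs from compound 3 in that same region: a group of 8 heavy atoms (5 carbon, 2 nitrogen, 1 oxygen; one five-membered aromatic ring with 3 hetero atoms) in place of a group of 9 heavy atoms (5 carbon, 1 oxygen, 3 fluorine; one four-membered non-aromatic ring of carbon only), on a carbonyl carbon. Going by the values given here, none of the measured steps covers this kind of exchange, since all three measured compounds keep an oxygen on the carbonyl carbon and differ only in what sits on that oxygen. What they do show is that this region tolerates a bulky group well and a smaller one poorly. Among the compounds with values here, with no direct precedent, the estimate for compound 4 is wide: a value of 40 nM is expected, between 8 nM and 200 nM, corresponding to an expected step of a 2.8-fold higher number from compound 3 to compound 4 (0.45 log units; beyond the scatter).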

Compound 4, half-maximal effective concentration: 21.2 nM
The estimate for compound 4 lay 1.9-fold (0.28 log units) above the measured number; the range from low to high includes it.
By their numbers in this assay, from the lowest: compounds 3, 1 and 4 (each within the scatter of the next); then compound 2.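

In this assay the carbonyl carbon proves not to need an oxygen: with 5-isopropyl-1,2,4-oxadiazol-3-yl bonded directly to it, a step of a 1.5-fold higher number from compound 3 to compound 4 (0.17 log units; within the scatter) and a step of a 1.1-fold higher number from compound 1 to compound 4 (0.03 log units; within the scatter) both stay within the scatter. The new ring group also stands well clear of the 1-(fluoromethyl)ethyl carbonyl substituent, with a 9.2-fold lower number from compound 2 to compound 4 (0.97 log units; beyond the scatter) on that exchange, so the sensitivity seen among the earlier groups is not a demand for the oxygen itself. Nothing available here explains why these different groups read alike.

Only one ring group is shown, so it remains open how a cyclopropyl or tert-butyl group would read in place of the isopropyl. Also open, going by these compounds, is how an amine nitrogen bonded to the carbonyl carbon would read.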